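The source may report more compounds than this note shows. Statements on the series, on what has been measured and on what is new or still open speak of the compounds shown alone.

Working notes on the series, three compounds measured and one pending.

Compound 1 `Cc1cc(S(=O)(=O)/N=C(\N)n2nccc2-c2ccccc2)c(SCc2ccccc2)cc1Cl` sets the baseline: in an ADME assay on microsomes from liver (Homo sapiens) for metabolic stability, read by LC-MS, using NADPH, tested at 5 uM (a higher number here means that the compound lasts longer, a lower number that the compound disappears faster), compound 1 gives 0.0772 h. Compound 2 `Cc1cc(-c2ccccc2)n(/C(N)=N/S(=O)(=O)c2cc(C)c(Cl)cc2SCc2ccccc2)n1` carries a methyl in place of hydrogen on an aromatic carbon of the core, and in this assay compound 2 gives 0.0938 h; the step of a 1.2-fold higher number from compound 1 to compound 2 (0.08 log units; within the scatter). Compound 3 `Cc1cc(S(=O)(=O)/N=C(\N)n2nccc2-c2ccccc2)c(SCc2ccccc2C)cc1Cl` carries a methyl in place of hydrogen on an aromatic carbon of the benzyl group, and in this assay compound 3 gives 0.0802 h; the step of a 1.0-fold higher number from compound 1 to compound 3 (0.02 log units; within the scatter). Compound 2 has the highest of the three numbers, but all three sit within the scatter of one another, so no order among them can be read.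

Compound 4 `Cc1cc(-c2ccccc2)n(/C(N)=N/S(=O)(=O)c2cc(C)c(Cl)cc2SCc2ccccc2Cl)n1` is the pending compound. It differs from compound 2 in one place: chloro in place of hydrogen on an aromatic carbon. Going by the values given here, no measured step exchanges hydrogen for chloro. The nearest comparison is the methyl on the same benzyl group, the step from compound 1 to compound 3, which stayed within the scatter. On that basis the half-life of compound 4 is expected close to that of compound 2, the step of a 1.1-fold higher number from compound 2 to compound 4 (0.03 log units; within the scatter) being within the scatter. The estimate for compound 4 is 0.1 h, with a range of 0.05 h to 0.2 h.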

Compound 4, half-life: 0.163 h
The estimate for compound 4 lay 1.6-fold (0.21 log units) below the measured number; low and high end bracket the measured number.
By their numbers in this assay, from the lowest: compounds 1, 3, 2 and 4 (each within the scatter of the next, the first and the last beyond it).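

In this assay, chloro in place of hydrogen on an aromatic carbon of the benzyl group gives a step that stays within the scatter (a 1.7-fold higher number from compound 2 to compound 4 (0.24 log units; within the scatter)), so 2-chlorobenzyl and benzyl cannot be told apart on the core of compound 2. The methyl on the same benzyl group also stayed within the scatter (a 1.0-fold higher number from compound 1 to compound 3 (0.02 log units; within the scatter)), so two different groups now agree at this ring, though on two different parents and in only these two pairs. No measurement at hand bears on what lies behind the size of this step.

Going by these compounds, whether chloro gives a comparable step on the parent of compound 1 stays open. Also open, on these data alone, is how this assay would read with an amine, a carboxylic acid or a longer chain on the benzyl group in place of chloro.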